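This account rests on a few compounds, and the source may have more. Where it says the series, first, only, none or still open, it means among the compounds named here.

Measured so far:
compound 1 `O=C(/C=C\c1ccc([N+](=O)[O-])cc1)N1N=C(c2ccncc2)OC1c1c[nH]c2ccccc12` — in an ADME assay on PANC-1 cells (Homo sapiens) for cytotoxicity, read by MTT assay, with a stated time of 48 h (a higher number here means a weaker inhibitor of growth, a lower number a stronger inhibitor of growth), compound 1 gives only the assay limit, > 30 ug/mL.
compound 2 `O=C(/C=C\c1ccc(F)cc1)N1N=C(c2ccncc2)OC1c1c[nH]c2ccccc12` — in this assay compound 2 likewise gives only the assay limit, > 30 ug/mL.

The step that the two limits leave unreadable from compound 1 to compound 2 thus has no readable size, both values sitting at the limit (the limit of > 30 ug/mL in this assay, at which 2 of the 2 values shown sit). Compound 2 stands at that limit with no number of its own. Compound 3 `O=C(/C=C\c1ccc(Cl)cc1)N1N=C(c2ccncc2)OC1c1c[nH]c2ccccc12` differs from compound 2 by chloro in place of fluoro on an aromatic carbon. Only the unreadable step bears on this change, so no step beyond the scatter can be expected in either direction. Compound 3 is expected to sit again at or near the limit, estimated at 40 ug/mL (range 15 ug/mL to 100 ug/mL), a step that the limit leaves unreadable from compound 2 to compound 3.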

Compound 3, concentration for 50% growth inhibition: > 30 ug/mL
Compound 3 was reported as a limit (the forecaster's own chance of this, stated with the estimate: 70%); the middle value is on the limit's open side.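

No step can be read among compound 1, compound 2 and compound 3, as each value is only a limit: the limit of > 30 ug/mL in this assay, at which 3 of the 3 values shown sit.

The compounds shown leave open how the nitro, fluoro and chloro groups rank in this assay.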